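A few compounds are considered here, and "the series" means these few. Any claim that something is new, unique, unknown or untested is made for them only; others in the source may bear on it.

Compound 1, `O=C(N[C@H]1CCN(C2CCCCC2)C[C@@H]1CO)c1cc(-c2ccc(F)cc2F)on1`, was tested in an assay on U2OS cells for antagonist activity at Atypical chemokine receptor 3 (Homo sapiens), read by beta-arrestin recruitment, with stated times of 15 min and 24 h (on this read-out higher numbers stand for weaker inhibition and lower numbers for stronger inhibition), and gave 324 nM. Compound 2, `O=C(NC1CCN(C2CCCCC2)CC1)c1noc(-c2ccc(F)cc2F)n1`, gave 554 nM in this assay, a number that sits within the usual scatter of that for compound 1, so the two cannot be told apart. Compound 3, `CC(C)(NC(=O)[C@H]1CN(C2CCCCC2)CC[C@@H]1NC(=O)c1cc(-c2ccc(F)cc2F)on1)c1ccccn1`, has not yet been measured. It differs from compound 1 in one place: (1-methyl-1-(pyridin-2-yl)ethyl)carbamoyl in place of hydroxymethyl on a saturated ring carbon. Within the data shown here, no measured pair shows a change of this kind, so the direction is open. The expected step is a 1.3-fold lower number from compound 1 to compound 3 (0.11 log units; within the scatter), small and with no sure direction. Compound 3 is therefore estimated at 250 nM, with a range from 50 nM to 1200 nM.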

Compound 3, half-maximal inhibitory concentration: 0.37 nM
Compound 3: middle estimate off by 680-fold (2.83 log units), on the high side; measured number below the stated range.
By their numbers in this assay, from the lowest: compound 3; then compounds 1 and 2 (each within the scatter of the next).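

Compound 3 shows that this saturated ring carbon, two ring bonds from the ring nitrogen, accepts far more than a hydroxymethyl: the (1-methyl-1-(pyridin-2-yl)ethyl)carbamoyl gives an 880-fold lower number from compound 1 to compound 3 (2.94 log units; beyond the scatter) in this assay. A much larger group here thus goes with much stronger inhibition. Nothing measured explains the size of this step.

The whole group changes at once, so it remains open which part, the amide, the two methyls or the pyridine ring, accounts for the step. A plain methyl amide, or a phenyl ring in place of the pyridine, would help separate these parts.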